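From compound 3 to compound 4: swapping one aromatic group

A few compounds are considered here, and "the series" means these few. Any claim that something is new, unique, unknown or untested is made for them only; others in the source may bear on it.

- compound 1 `O=C1/C(=C\c2ccc([N+](=O)[O-])cc2)S/C(=N/c2ccccc2)N1Cc1ccncc1` gives 250000 nM
- compound 2 `CC(C)c1ccc(/C=C2/S/C(=N/c3ccccc3)N(Cc3ccncc3)C2=O)cc1` gives 137000 nM
- compound 3 `CCOc1cc(/C=C2/S/C(=N/c3ccccc3)N(Cc3ccncc3)C2=O)ccc1O` gives 46500 nM

In an ADME assay on HEK293 cells (Homo sapiens) for cytotoxicity, read by MTT assay, with a stated time of 48 h (on this read-out lower numbers stand for stronger inhibition and higher numbers for weaker inhibition), compound 3 gives 46500 nM and this is the lowest of the three numbers. For the measured compounds named here, compound 4 `O=C1/C(=C\c2ccccn2)S/C(=N/c2ccccc2)N1Cc1ccncc1` differs at one place, with pyridin-2-yl in place of 3-ethoxy-4-hydroxyphenyl on a double-bonded chain carbon bound to a double-bonded ring carbon and no measured compound carries pyridin-2-yl. Two measured steps arrive at the departing group: a 2.9-fold lower number from compound 2 to compound 3 (0.47 log units; beyond the scatter) and also a 5.4-fold lower number from compound 1 to compound 3 (0.73 log units; beyond the scatter) and each is modest. Removing that group should therefore undo part of this drop, though the size remains uncertain. The step expected in this assay is a 2.6-fold higher number from compound 3 to compound 4 (0.41 log units; beyond the scatter) toward a higher number. The estimate for compound 4 is 120000 nM with 50000 nM to 250000 nM as the expected range.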

Compound 4, half-maximal inhibitory concentration: 161000 nM
The estimate for compound 4 lay 1.3-fold (0.13 log units) below the measured number; measured number inside the range.
By their numbers in this assay, from the lowest: compound 3; then compounds 2, 4 and 1 (each within the scatter of the next).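

In this assay there is a 3.5-fold higher number from compound 3 to compound 4 (0.54 log units; beyond the scatter), so a third replacement for 3-ethoxy-4-hydroxyphenyl at this place also gives a higher number. Pyridin-2-yl, with fewer heavy atoms and no hydrogen-bond donor, does not separate from the other two replacements: there is a 1.2-fold higher number from compound 2 to compound 4 (0.07 log units; within the scatter) and a 1.6-fold lower number from compound 1 to compound 4 (0.19 log units; within the scatter). Nothing available here explains the gap to compound 3. Still open, as far as these compounds go, is whether 4-hydroxyphenyl or 3-ethoxyphenyl alone would give a number like that of compound 3. Also open, from the compounds shown here alone, is whether pyridin-3-yl would match pyridin-2-yl.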